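The compounds below may be only part of what the source reports. "The series", "measured", "known", "first", "only" and "open" are said of these compounds alone.

Measured compounds in a functional assay on the whole organism (strain Swiss) with Mus musculus as the target, in the maximal electroshock model, with a stated time of 0.5 h, at a dose of 300 mg/kg by the intraperitoneal route; a lower number here means a weaker effect, a higher number a stronger effect of the compound at the dose given:

- compound 1, `COc1cccc(N2CCN(C(=O)C(C)N3C(=O)CCC3=O)CC2)c1`: 50%
- compound 2, `CC(C(=O)N1CCN(c2ccc(Cl)cc2)CC1)N1C(=O)CCC1=O`: 100%
- compound 3, `CC(C(=O)N1CCN(c2cccc(C(F)(F)F)c2)CC1)N1C(=O)CCC1=O`: 100%

Compound 3 stands level with compound 2 at the digits printed, the two together being the highest of the three numbers; compound 1 lies a full step below, the gap being beyond the scatter.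

Compound 4, `CC(C(=O)N1CCN(c2cccc(Cl)c2)CC1)N1C(=O)CCC1=O`, is not yet measured. It differs from compound 3 by chloro in place of trifluoromethyl on an aromatic carbon.

Within the data shown here, two measured steps bear on this. The step of a number 50 percentage points higher from compound 1 to compound 3 (beyond the scatter) was obtained at the same aromatic carbon, so the trifluoromethyl compound is the upper reference. The step of a number 50 percentage points higher from compound 1 to compound 2 (beyond the scatter) shows that a chloro substituent on the aryl ring, there as 4-chlorophenyl, also reaches the top of the range. Both halogenated and trifluoromethyl compounds sit at the maximum, so no step beyond the scatter is expected, with at most a modest downward movement a number 10 percentage points lower from compound 3 to compound 4 (within the scatter) in this assay, since the read-out cannot rise further.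

Compound 4 is therefore expected to give 90%, with a range of 60% to 100%.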

Compound 4, a percentage reported as activity, at one dose (the size of the read-out at that dose, not a potency): 100%
Estimate against measurement, compound 4: 10 percentage points below; the measured number falls inside the stated range.
By their numbers in this assay, from the lowest: compound 1; then compounds 2, 3 and 4 (each within the scatter of the next).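

In this assay, the change on an aromatic carbon meta to a large group gives no change at the digits printed from compound 3 to compound 4 (within the scatter) when chloro, with one heavy atom, replaces trifluoromethyl, with four, so the series keeps its top printed value with either group at this place. The chloro group also reads the same on the 3-chlorophenyl and 4-chlorophenyl compounds, with no change at the digits printed from compound 2 to compound 4 (within the scatter) in this comparison, while a number 50 percentage points higher from compound 1 to compound 4 (beyond the scatter) adds a third non-methoxy compound standing clear of compound 1. No measurement here gives a reason for these steps.

Compounds 2, 3 and 4 all sit at the same printed value at a single dose, so any difference among them stays unresolved without readings at lower doses. As far as these compounds go, it also remains open whether a fluoro, nitrile, amine or carboxylic acid group on this aromatic carbon would hold that value or fall towards compound 1.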